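Moving the hydroxyl in the trifluoromethyl member of the series

The compounds below may be only part of what the source reports. "The series", "measured", "known", "first", "only" and "open" are said of these compounds alone.

Compound 3 `Oc1ccc(-c2cc(-c3cccc(C(F)(F)F)c3)cc(-c3cccc(O)c3)n2)cc1` gives 11100 nM in a functional assay on DU-145 cells (Homo sapiens) for inhibition; a higher number here means a weaker inhibitor, a lower number a stronger inhibitor. Among the three measured compounds this is the highest number, but its gap to compound 1 `Oc1ccc(-c2cc(-c3cccc(F)c3)cc(-c3ccc(O)cc3)n2)cc1`, which gives 9290 nM, and to compound 2 `Oc1ccc(-c2cc(-c3ccc(F)cc3)cc(-c3ccc(O)cc3)n2)cc1`, which gives 6030 nM, is each within the scatter, so the three stand together as one band. Compound 4 `Oc1ccc(-c2cc(-c3cccc(C(F)(F)F)c3)cc(-c3ccc(O)cc3)n2)cc1` differs from compound 3 in one place: 4-hydroxyphenyl in place of 3-hydroxyphenyl on an aromatic carbon. For the measured compounds named here, no measured pair moves a hydroxyl from one ring position to another. Going by the values given here, the only measured step, a 1.5-fold lower number from compound 1 to compound 2 (0.19 log units; within the scatter), moves a fluorine on a different aryl ring and stays within the scatter; it is the nearest precedent and points to no change beyond the scatter here either. Compound 4 also carries the same pair of 4-hydroxyphenyl groups as compound 1 and compound 2, whose numbers lie in the same band as compound 3. The expected step is therefore a 1.4-fold lower number from compound 3 to compound 4 (0.14 log units; within the scatter), not beyond the scatter. Compound 4 is estimated at 8000 nM, with a range from 3000 nM to 20000 nM.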

Compound 4, half-maximal inhibitory concentration: > 50000 nM
Compound 4: only a limit was reported; the forecaster's own chance of this, stated with the estimate: 5%; at least 6.2-fold (0.79 log units) between middle value and limit.
By their numbers in this assay, from the lowest: compounds 2, 1 and 3 (each within the scatter of the next). At a limit, above all of these: compound 4.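

In this assay compound 4 gives only a limit of the assay, the one such value among the compounds shown: the limit of > 50000 nM in this assay, at which 1 of the 4 values shown sits.

At this position next to the ring nitrogen, the step of an at least 4.5-fold higher number from compound 3 to compound 4 (0.65 log units; beyond the scatter) shows that 4-hydroxyphenyl in place of 3-hydroxyphenyl is not a neutral swap, although the two groups have the same atoms; the earlier fluorine shift stayed within the scatter and did not show this. With the pair of 4-hydroxyphenyl groups held constant, the other aryl position is also sensitive: the series gives an at least 5.3-fold higher number from compound 1 to compound 4 (0.73 log units; beyond the scatter) and an at least 8.2-fold higher number from compound 2 to compound 4 (0.91 log units; beyond the scatter), so 3-(trifluoromethyl)phenyl is not interchangeable with either fluorophenyl group in this setting.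

Open, as far as these compounds go, is whether the same hydroxyl shift has a comparable effect when the other aryl group is 3-fluorophenyl or 4-fluorophenyl. Also open, from the compounds shown here alone, is how an amine or a methoxy group on this ring would compare with either hydroxyl placement.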